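Chloro for Vinyl on a Weakly Active Sulfonamide

The compounds below may be only part of what the source reports. "The series", "measured", "known", "first", "only" and "open" are said of these compounds alone.

Compound 1 `C=Cc1ccc(S(=O)(=O)Nc2ccc(-c3nc4ccccc4o3)cc2)cc1` was examined in an assay on cells for inhibition of HSP60/HSP10 (Homo sapiens), with a stated time of 60 min; on this read-out higher numbers stand for weaker inhibition and lower numbers for stronger inhibition. In this assay compound 1 gives > 100000 nM, a value that is a limit of the assay and not a measured number. Its standing is summed up by the limit of > 100000 nM in this assay, at which 1 of the 2 values shown sits, so compound 1 is known only to be a weak inhibitor, with no exact figure. Among the compounds with values here, compound 2 `O=S(=O)(Nc1ccc2oc(-c3ccccc3)nc2c1)c1ccc(Cl)s1`, a sulfonamide built on a differently arranged version of the shared core, gives 70000 nM in this assay; no single-point step links compound 2 to compound 1, so the two values may only be set side by side, and both point to weak inhibition.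

Compound 3 `O=S(=O)(Nc1ccc(-c2nc3ccccc3o2)cc1)c1ccc(Cl)cc1` has not yet been measured. It differs from compound 1 by chloro in place of vinyl on an aromatic carbon. With compound 1 known only through its limit, the step from compound 1 to compound 3 is expected to stay within the scatter, and the estimate is a number no higher from compound 1 to compound 3 (the limit leaves the size open), with no direction that can be supported. Compound 3 is therefore estimated at 100000 nM, within a range from 40000 nM to 300000 nM, and a limit rather than a number is expected to be the most likely outcome.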

Compound 3, half-maximal inhibitory concentration: 61000 nM
Estimate against measurement, compound 3: 1.6-fold (0.21 log units) above, within the range that was stated.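

In this assay compound 3 gives 61000 nM, so with chloro at this place, para to a large group, the core of compound 1 yields an exact number, which compound 1 itself does not provide, and inhibition at this position is still weak. From the compounds shown here alone, compound 1 is known only through > 100000 nM, which is a limit of the assay and not a number, and this bounds all that can be read from the pair: the limit of > 100000 nM in this assay, at which 1 of the 3 values shown sits. The change from 4-vinylphenyl to 4-chlorophenyl reads as an at least 1.6-fold lower number from compound 1 to compound 3 (0.21 log units; that floor lies within the scatter), so the printed floor of the step shows no change beyond the scatter, while its true size stays unknown.

The compounds shown leave open whether another group at this place on the six-membered ring, such as an amine, a carboxylic acid or a longer chain, would give a step that clears the scatter. They also leave open how large the step from vinyl to chloro really is, since only one side of it carries a number.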